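The source may report more compounds than this note shows. Statements on the series, on what has been measured and on what is new or still open speak of the compounds shown alone.

Of the compounds shown here, three sharing one core have been tested in an ADME assay on Vero cells (Chlorocebus sabaeus) for cytotoxicity, read by resazurin assay, with a stated time of 3 days; on this read-out lower numbers stand for stronger inhibition and higher numbers for weaker inhibition. Compound 1 `CCCc1ccc(C(=O)Nc2cc3nc(C4CCCCC4)[nH]c3cc2N(C)C)cc1` reaches only the limit of the assay, giving > 100 ug/mL. Compound 2 `CN(C)c1cc2[nH]c(C3CCCCC3)nc2cc1NC(=O)c1ccco1` likewise gives a limit, > 100 ug/mL. Compound 3 `CN(C)c1cc2[nH]c(C3CCCCC3)nc2cc1NC(=O)c1ccc(F)cc1F` also gives a limit, > 100 ug/mL. Because of the limit of > 100 ug/mL in this assay, at which 3 of the 3 values shown sit, none of the three results is a number, so compound 3 stands alongside the other two at the same limit and no order among them can be read.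

Compound 4 `CN(C)c1cc2[nH]c(C3CCCCC3)nc2cc1NC(=O)c1ccc(C(C)(C)C)cc1` is still to be measured; it differs from compound 3 by 4-(tert-butyl)phenyl in place of 2,4-difluorophenyl on a carbonyl carbon. The step bearing most directly on this change is a step that the two limits leave unreadable from compound 2 to compound 3; the related steps a step that the two limits leave unreadable from compound 1 to compound 3 and a step that the two limits leave unreadable from compound 1 to compound 2 are equally unreadable. Three different groups on a carbonyl carbon have thus all left cytotoxicity at the limit, so no step beyond the scatter is expected in this assay in either direction. The estimate for compound 4 is therefore 100 ug/mL, between 50 ug/mL and 200 ug/mL, meaning an expected step of a number no higher from compound 3 to compound 4 (the limit leaves the size open), with a high chance that only a limit is reported again.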

Compound 4, half-maximal inhibitory concentration: > 100 ug/mL
Compound 4: only a limit was reported (the forecaster's own chance of this, stated with the estimate: 75%); the middle value lies on the limit itself.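

In this assay compound 4 gives only a limit, so its steps to compound 1, compound 2 and compound 3 cannot be read, because all four compounds sit at the same limit: the limit of > 100 ug/mL in this assay, at which 4 of the 4 values shown sit. Going by these compounds, the concentration at which any of these four compounds would harm the cells remains open.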